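Swapping methoxy for bromo on a benzimidazole acetic acid

A few compounds are considered here, and "the series" means these few. Any claim that something is new, unique, unknown or untested is made for them only; others in the source may bear on it.

Of the compounds shown here, three have been measured in an assay on HEK293 cells for displacement of a labelled ligand from prostaglandin D2 receptor 2 (Homo sapiens); on this read-out lower numbers stand for stronger inhibition and higher numbers for weaker inhibition. Compound 1 `CCOC(=O)CCCSc1nc2ccccc2n1CC(=O)O` gives 4410 nM, compound 2 `O=C(O)Cn1c(SCc2cccc(Cl)c2)nc2ccccc21` gives 186 nM, and compound 3 `COc1ccc(CSc2nc3ccccc3n2CC(=O)O)cc1` gives 210 nM. Compound 3 thus stands second highest of the three numbers; its nearest neighbour is compound 2, within the scatter, while compound 1 lies well above it, beyond the scatter. Among the measured compounds shown here, the one single-point step recorded is a 24-fold lower number from compound 1 to compound 2 (1.37 log units; beyond the scatter), a large change that bears on the group carried on the saturated chain carbon bound to sulfur rather than on a substituent of the aromatic ring.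

Compound 4 `O=C(O)Cn1c(SCc2ccc(Br)cc2)nc2ccccc21` differs from compound 3 by bromo in place of methoxy on an aromatic carbon. For the measured compounds named here, no measured step isolates such a swap; the only guidance is that compound 2, bearing a halogen, and compound 3, bearing methoxy, give numbers within the scatter of each other. In this assay the step of a 1.3-fold lower number from compound 3 to compound 4 (0.12 log units; within the scatter) is therefore expected to be small, in no firm direction. Compound 4 is estimated at 160 nM, with a range from 50 nM to 500 nM.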

Compound 4, half-maximal inhibitory concentration: 220 nM
For compound 4 the middle estimate is 1.4-fold (0.14 log units) below the measured one; the range from low to high includes it.
By their numbers in this assay, from the lowest: compounds 2, 3 and 4 (each within the scatter of the next); then compound 1.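

In this assay the swap of methoxy for bromo on an aromatic carbon, para to a large group, can now be read directly: it gives a 1.0-fold higher number from compound 3 to compound 4 (0.02 log units; within the scatter) and so leaves the number unchanged within the scatter. The comparison of the two halogen-bearing compounds gives a 1.2-fold higher number from compound 2 to compound 4 (0.07 log units; within the scatter) and does not separate 4-bromophenyl from 3-chlorophenyl on the saturated chain carbon bound to a sulfur, whereas replacing 2-(ethoxycarbonyl)ethyl with 4-bromophenyl gives a 20-fold lower number from compound 1 to compound 4 (1.30 log units; beyond the scatter) and, like the earlier step with 3-chlorophenyl, lies beyond the scatter. No supporting evidence accompanies these results that would account for them.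

The compounds shown leave open whether an amine or a nitrile, para to a large group, would also give a number within the scatter of these. They also leave open how the number would respond if a hydroxy group or a longer chain stood on that ring carbon.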